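The compounds below may be only part of what the source reports. "The series", "measured", "known", "first", "only" and "open" are said of these compounds alone.

Measured so far:
- compound 1, `COc1cccc(OC)c1C(=O)Nc1c[nH]nc1C(=O)NC1CCCCCC1`: 42000 nM
- compound 2, `CO[C@H]1CC[C@H](NC(=O)c2n[nH]cc2NC(=O)c2ccc(-c3ccccc3)o2)CC1`: 100 nM

In an ADME assay on MRC5 cells (Homo sapiens) for inhibition, with a stated time of 72 h (a lower number here means that less compound is needed, a higher number that more compound is needed for the effect), compound 1 gives the higher of these two numbers, and compound 2 gives the lower one. For the measured compounds named here, no step between two measured compounds is available for the change now considered.

Compound 3, `COCCNC(=O)c1n[nH]cc1NC(=O)c1c(OC)cccc1OC`, is the one to be measured. It differs from compound 1 in one place: 2-methoxyethyl in place of cycloheptyl on an amide-type nitrogen.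

Going by the values given here, with no measured step to lean on, a modest step from compound 1 to compound 3 is expected in this assay, towards a higher number. The estimated value for compound 3 is 60000 nM, in a range from 15000 nM to 250000 nM, an expected step of a 1.4-fold higher number from compound 1 to compound 3 (0.15 log units; within the scatter).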

Compound 3, half-maximal effective concentration: > 50000 nM
Compound 3: a limit, no number; the forecaster's own chance of this, stated with the estimate: 25%; the middle value is on the limit's open side.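

In this assay, compound 3 gives > 50000 nM, which is a limit of the assay and not a number. Putting 2-methoxyethyl in place of cycloheptyl on this amide-type nitrogen therefore gives only a floor for the step, an at least 1.1-fold higher number from compound 1 to compound 3 (0.07 log units; that floor lies within the scatter), and nothing here shows this change lowering the number. The true size of the step stays unknown, and the only reading available is bounded: the limit of > 50000 nM in this assay, at which 1 of the 3 values shown sits.

Still open, on these data alone, is whether an amine, a carboxylic acid or a longer chain on this amide-type nitrogen would bring the number down into a measurable range.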